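The compounds below may be only part of what the source reports. "The series", "measured", "known", "first", "only" and "open" are said of these compounds alone.

Three compounds have been measured so far in a physicochemical assay for lipophilicity (a higher number here means a more lipophilic compound, a lower number a more polar compound), and their results are these

compound 1 `CC(=O)Nc1cc(Cl)cc2[nH]c(C)nc12` gives 1.27
compound 2 `c1ccc(OCCc2nc3ccccc3[nH]2)cc1` gives 3.16
compound 3 `Cc1cc(C)cc(OCc2nc3ccccc3[nH]2)c1` gives 3.5

Compound 3 stands highest of the three. Its gap to compound 2 lies beyond the scatter of repeated measurements, and so does its much wider gap to compound 1.

The next compound, compound 4 `Cc1cc(OCc2nc3ccccc3[nH]2)cc(C)c1Cl`, differs from compound 3 in a single place, which makes this a clean comparison. The difference is chloro in place of hydrogen on an aromatic carbon and amounts to chloro in place of hydrogen on an aromatic carbon, ortho to two methyl groups and para to a large group. Within the data shown here, no pair of measured compounds here shows this change or any other single change, so the expectation is a judgement from the structural change alone. An upward move of a number 0.60 log units higher from compound 3 to compound 4 (beyond the scatter) is expected in this assay and would lie beyond the scatter. For compound 4 the estimated value is 4.1 with an expected range from 3.7 to 4.5 around it.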

Compound 4, partition coefficient: 4.43
The estimate for compound 4 lay 0.33 log units below the measured number; the measured number falls inside the stated range.
By their numbers in this assay, from the lowest: compound 1; then compound 2; then compound 3; then compound 4.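

In this assay, among these compounds, putting chloro in place of hydrogen on an aromatic carbon, ortho to two methyl groups and para to a large group, gives a number 0.93 log units higher from compound 3 to compound 4 (beyond the scatter), the first change in a single place that can be read in this set. It shows that one added chlorine atom, with no ring, no hydrogen-bond donors or acceptors and no net charge, is enough at this position to move the number beyond the scatter of repeated measurements. Nothing available here accounts for the size of this step.

On these data alone, whether an amine or a methoxy group at this same position would move the number in the same direction remains open. One pair also cannot show whether chloro would give a similar step without the two methyl groups, or on another aromatic carbon.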